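The compounds below may be only part of what the source reports. "The series", "measured", "known", "first", "only" and "open" are said of these compounds alone.

Measured compounds:
compound 1 `Cc1cc(=O)n(-c2ccccc2OC(F)(F)F)nc1C(=O)Nc1ccc(Oc2ncnc3ccsc23)cc1` gives 23800 nM in a functional assay on MCF7 cells (Homo sapiens) for cytotoxicity, read by MTT assay, with a stated time of 72 h; on this read-out higher numbers stand for weaker inhibition and lower numbers for stronger inhibition;
compound 2 `Cc1cc(=O)n(-c2ccccc2C(F)(F)F)nc1C(=O)Nc1ccc(Oc2ncnc3ccsc23)c(F)c1` gives 6020 nM;
compound 3 `Cc1cc(=O)n(-c2ccc(Br)cc2F)nc1C(=O)Nc1ccc(Oc2ncnc3ccsc23)c(F)c1` gives 1550 nM.

Compound 3 stands at the lowest number of the three, ahead of compound 2 and, by a wider margin, of compound 1. Among the measured compounds shown here, the one step between measured neighbours, a 3.9-fold lower number from compound 2 to compound 3 (0.59 log units; beyond the scatter), shows that swapping the group on the aromatic nitrogen can move the number by a modest amount.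

Compound 4 `Cc1cc(=O)n(-c2ccccc2OC(F)(F)F)nc1C(=O)Nc1ccc(Oc2ncnc3ccsc23)c(F)c1` is the next step: 2-(trifluoromethoxy)phenyl in place of 4-bromo-2-fluorophenyl on an aromatic nitrogen. For the measured compounds named here, this change returns to the group carried by compound 1, which shares everything else with compound 4 except the fluorine on the anilide ring; no measured pair isolates that fluorine, so its own contribution is unknown. Compound 2 and compound 3, which both carry that fluorine, sit well under compound 1. The step to compound 4 is therefore expected to move the number upward, estimated as a 6.5-fold higher number from compound 3 to compound 4 (0.81 log units; beyond the scatter), because compound 1 gives 23800 nM with the same group on the aromatic nitrogen. Compound 4 is expected at about 10000 nM, within a range from 3000 nM to 30000 nM.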

Compound 4, half-maximal inhibitory concentration: 11500 nM
Estimate against measurement, compound 4: 1.2-fold (0.06 log units) below, within the range that was stated.
By their numbers in this assay, from the lowest: compound 3; then compounds 2 and 4 (each within the scatter of the next); then compound 1.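

In this assay, among the compounds shown here, fluoro in place of hydrogen on an aromatic carbon gives a 2.1-fold lower number from compound 1 to compound 4 (0.32 log units; beyond the scatter) as a modest step, the first measured pair to isolate that fluorine. Trifluoromethoxy in place of trifluoromethyl gives a 1.9-fold higher number from compound 2 to compound 4 (0.28 log units; within the scatter) and stays within the scatter, so these two groups cannot be told apart on this read-out. Changing the whole group on the aromatic nitrogen gives a 7.4-fold higher number from compound 3 to compound 4 (0.87 log units; beyond the scatter) with 2-(trifluoromethoxy)phenyl in place of 4-bromo-2-fluorophenyl, which shows that compound 3 keeps its lower number against a second group at this position.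

From the compounds shown here alone, whether the fluoro step holds with other groups on the aromatic nitrogen remains open, as does the effect of a phenyl ring carrying an amine or a carboxylic acid there. Nothing measured here accounts for these steps.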